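The source may report more compounds than this note shows. Statements on the series, on what has been measured and on what is new or still open speak of the compounds shown alone.

The compounds measured so far in a functional assay on MDA-MB-231 cells (Homo sapiens) for antiproliferative activity, read by MTT assay, with a stated time of 48 h; a lower number here means a stronger inhibitor, a higher number a weaker inhibitor:

Compound 1, `Cc1ccc2nc(Nc3nc(Nc4ccc(S(C)(=O)=O)cc4)ncc3F)sc2c1`, gives 14300 nM.
Compound 2, `CS(=O)(=O)c1ccc(Nc2nccc(Nc3nc4ccc(F)cc4s3)n2)cc1`, gives 2080 nM.
Compound 3, `Cc1cnc(Nc2ccc(S(C)(=O)=O)cc2)nc1Nc1nc2ccc(F)cc2s1`, gives only a limit, > 50000 nM.

Compound 2 holds the lowest number among the two compounds with a number in this assay; compound 1 sits at a clearly higher number, and compound 3 reaches only the limit (the limit of > 50000 nM in this assay, at which 1 of the 3 values shown sits). Compound 4, `Cc1ccc2nc(Nc3ccnc(Nc4ccc(S(C)(=O)=O)cc4)n3)sc2c1`, is drawn from compound 2 by a single change: methyl in place of fluoro on an aromatic carbon. For the measured compounds named here, the one step measured here, an at least 24-fold higher number from compound 2 to compound 3 (1.38 log units; beyond the scatter), concerns a methyl entering on the other aromatic ring and is of no direct bearing on the benzothiazole side; compounds 1 and 2, which differ in two places, show a smaller gap. Going by the values given here, no measured step isolates methyl against fluoro on this ring, so she expects the change from compound 2 to compound 4 to be modest, most likely a somewhat higher number: a 1.9-fold higher number from compound 2 to compound 4 (0.28 log units; within the scatter). Compound 4 is thus estimated at 4000 nM, between 1000 nM and 16000 nM.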

Compound 4, half-maximal inhibitory concentration: 4440 nM
Compound 4: middle estimate off by 1.1-fold (0.05 log units), on the low side, within the range that was stated.
By their numbers in this assay, from the lowest: compound 2; then compound 4; then compound 1. At a limit, above all of these: compound 3.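

In this assay, the methyl and fluoro exchange on the six-membered aromatic ring of carbon only has a modest effect, a 2.1-fold higher number from compound 2 to compound 4 (0.33 log units; beyond the scatter), so this position accepts either group with little difference in the number. Compound 4 also opens a view of the other aromatic ring: there, hydrogen in place of fluoro gives a 3.2-fold lower number from compound 1 to compound 4 (0.51 log units; beyond the scatter). On that ring, hydrogen gives the lower number in both available comparisons, since methyl in place of hydrogen gives an at least 24-fold higher number from compound 2 to compound 3 (1.38 log units; beyond the scatter), a step that ends at a limit of the assay.

As far as these compounds go, whether an amine, a methoxy group or a longer chain would be accepted at the place held by methyl and fluoro stays open, as does the effect of hydrogen there. Nothing shown offers a reason for either of these steps.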